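Swapping the Amine Partner on a Sulfonyl Group

The compounds below may be only part of what the source reports. "The series", "measured", "known", "first", "only" and "open" are said of these compounds alone.

Of the compounds shown here, three built on one shared core have been measured in an assay on CHO cells for displacement of a labelled ligand from prostaglandin D2 receptor 2 (Homo sapiens), read by scintillation counting; on this read-out higher numbers stand for weaker inhibition and lower numbers for stronger inhibition. Compound 1 `COCCN(C)S(=O)(=O)c1ccc(C)c(C#Cc2cc(Cl)ccc2OCC(=O)O)c1` gives 4.1 nM in this assay, the second highest of the three numbers. Compound 3 `CCCS(=O)(=O)c1ccc(C)c(C#Cc2cc(Cl)ccc2OC(C)C(=O)O)c1` gives the lower value 1.2 nM, while compound 2 `CN(c1cccc(C#Cc2cc(Cl)ccc2OCC(=O)O)c1)S(C)(=O)=O` gives the higher value 122 nM. The next compound, compound 4 `Cc1ccc(S(=O)(=O)N2CCN(C)CC2)cc1C#Cc1cc(Cl)ccc1OCC(=O)O`, is compound 1 with a single change: 4-methylpiperazin-1-yl in place of (2-methoxyethyl)(methyl)amino on a sulfonyl sulfur. For the measured compounds named here, no step between measured compounds isolates this kind of change, so the expectation rests on compound 1 itself. Because compound 1 already sits at 4.1 nM, the step of a 1.5-fold higher number from compound 1 to compound 4 (0.17 log units; within the scatter) is expected to be small, either within the scatter or a modest weakening. Compound 4 is therefore estimated at 6 nM, with a likely range from 2 nM to 20 nM.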

Compound 4, inhibition constant: 21 nM
For compound 4 the middle estimate is 3.5-fold (0.54 log units) below the measured one; the measured number lies above the stated range.
By their numbers in this assay, from the lowest: compound 3; then compound 1; then compound 4; then compound 2.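

Changing the amine partner on this sulfonyl sulfur is not a neutral swap: a 5.1-fold higher number from compound 1 to compound 4 (0.71 log units; beyond the scatter) shows weaker inhibition, a step beyond the usual scatter. The shift occurs even though the leaving and entering groups each count one hydrogen-bond acceptor, no donors and no net charge, so those counts alone do not predict the result here. No available measurement explains the weakening.

From the compounds shown here alone, it remains open whether a morpholine ring, a dimethylamino group or a piperazine lacking its methyl group would stay closer to compound 1.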